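Replacing the nitrile by a longer acetyl-bearing chain

This account rests on a few compounds, and the source may have more. Where it says the series, first, only, none or still open, it means among the compounds named here.

Compound 3 `C=CCc1cc(C(C)=O)c(O)cc1OCC#N` gives 2% in an assay on isolated protein for binding affinity to leukotriene B4 receptor 1 (Homo sapiens), tested at 1 uM (on this read-out lower numbers stand for less inhibition and higher numbers for more inhibition at the one concentration tested (going by the name of the read-out)), the lowest of the three numbers shown, though compound 2 `CC(=O)c1cc(C=O)c(OCCCCC#N)cc1O` with 3% lies within the scatter of it, while compound 1 `CC(=O)c1cc(CC2CO2)c(OCCCCC#N)cc1O` with 24% lies beyond it. Compound 4 `C=CCc1cc(C(C)=O)c(O)cc1OCCCCCC(C)=O` differs from compound 3 in one place: 4-acetylbutyl in place of cyano on a saturated chain carbon bound to an oxygen on an aromatic ring. Within the data shown here, the only step measured between compounds differing in one place, a number 21 percentage points lower from compound 1 to compound 2 (beyond the scatter), concerns a different group on the aromatic ring and does not bear on this change. Among the measured compounds shown here, compound 1 and compound 3 differ in more than one place; their two values show only that compound 1 is higher. Compound 4 is therefore expected to sit at 12%, between 0% and 35%. This estimate means an expected step of a number 10 percentage points higher from compound 3 to compound 4 (within the scatter).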

Compound 4, a percentage reported as inhibition, at one concentration (the size of the read-out at that concentration, not a potency): 58%
Compound 4: the middle estimate sits 46 percentage points below what was measured; the whole stated range lies below it.
By their numbers in this assay, from the lowest: compounds 3 and 2 (each within the scatter of the next); then compound 1; then compound 4.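

The place on a saturated chain carbon bound to an oxygen on an aromatic ring proves highly sensitive in this assay: 4-acetylbutyl in place of cyano gives a number 56 percentage points higher from compound 3 to compound 4 (beyond the scatter), the first step shown at this place. The change enlarges the group while leaving its count of hydrogen-bond acceptors the same, so that count does not track the step. No measurement here explains the gain.

Going by these compounds, it remains open whether the chain or its terminal acetyl carries the step; a plain alkyl chain or one ending in a carboxylic acid would separate the two. On these data alone, whether the step holds with formyl or (oxiran-2-yl)methyl on the ring also remains open.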